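Thiophen-2-yl to 4-chlorobenzyl on the shared core

The source may hold more compounds than are shown below. What is called first, only, known or untested is meant among the compounds shown, and "the series" means these compounds.

Measured in an ADME assay on HEK-293T cells (Homo sapiens) for inhibition, read by CCK-8 assay, with a stated time of 48 h, tested at 20 uM; on this read-out higher numbers stand for more inhibition of growth at the one concentration tested and lower numbers for less inhibition of growth:
- compound 1 `COc1ccc(S(=O)(=O)Oc2ccccc2/C=C(\C#N)C(=O)Nc2nnc(-c3cccs3)s2)cc1`: 40%
- compound 2 `N#C/C(=C\c1ccccc1OS(=O)(=O)c1ccc([N+](=O)[O-])cc1)C(=O)Nc1nnc(-c2cccs2)s1`: 33%
- compound 3 `N#C/C(=C\c1ccccc1OS(=O)(=O)c1ccccc1[N+](=O)[O-])C(=O)Nc1nnc(Cc2ccc(F)cc2)s1`: 6%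

Compound 2 at 33% lies within the scatter of compound 1. Compound 3 stands at 6%. The gap between compound 2 and compound 3 lies beyond the scatter. The next step leads to compound 4 `N#C/C(=C\c1ccccc1OS(=O)(=O)c1ccc([N+](=O)[O-])cc1)C(=O)Nc1nnc(Cc2ccc(Cl)cc2)s1`: 4-chlorobenzyl in place of thiophen-2-yl on an aromatic carbon, in words 4-chlorobenzyl in place of thiophen-2-yl on an aromatic carbon. For the measured compounds named here, the only measured step, a number 7 percentage points lower from compound 1 to compound 2 (within the scatter), concerns a different place and says little here. The nearest guide is compound 3 at 6%, which carries a fluorine-bearing benzyl group at that place but also differs from compound 2 elsewhere. A lower number is therefore expected in this assay, an estimated a number 18 percentage points lower from compound 2 to compound 4 (beyond the scatter). For compound 4 the estimate is 15%, with an expected range of 3% to 35%.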

Compound 4, percent growth inhibition at one concentration: 19%
Beside the measured number, compound 4's estimate is 4 percentage points below it; the measured number falls inside the stated range.
By their numbers in this assay, from the lowest: compound 3; then compound 4; then compounds 2 and 1 (each within the scatter of the next).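

In this assay, this aromatic carbon of the shared core now has its first single-place reading: 4-chlorobenzyl in place of thiophen-2-yl gives a number 14 percentage points lower from compound 2 to compound 4 (beyond the scatter). For the compounds shown here, the position therefore moves the read-out, whereas the only earlier step, on the other aromatic ring, did not leave the scatter. The data on hand offer no explanation for this step.

Open, on these data alone, is whether the change in growth inhibition follows the benzyl frame or its chlorine. An unsubstituted benzyl group or an aminomethyl group at this carbon would extend the comparison.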